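This account rests on a few compounds, and the source may have more. Where it says the series, first, only, none or still open, it means among the compounds named here.

Compound 1 `Cc1ccoc1C(=O)N1CCC(NC(=O)Nc2ccc(C(F)(F)F)cc2)CC1` carries a trifluoromethyl group on an aromatic carbon of a six-membered aromatic ring of carbon only, and a 3-methylfuran-2-yl group on a carbonyl carbon. In a physicochemical assay for solubility, read by mass spectrometry, in phosphate buffer, with a stated time of 24 h, at pH 7.4 (on this read-out higher numbers stand for higher solubility and lower numbers for lower solubility), compound 1 gives 0.8 ug/mL. Compound 2 `Cc1ccoc1C(=O)N1CCC(NC(=O)Nc2ccc(OC(F)(F)F)cc2)CC1` differs from compound 1 in one place, (trifluoromethoxy in place of trifluoromethyl on an aromatic carbon), and in this assay compound 2 gives 0.92 ug/mL. The step of a 1.2-fold higher number from compound 1 to compound 2 (0.06 log units; within the scatter) is small and lies within the usual scatter of repeated measurements, so the two numbers cannot be told apart with confidence.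

Compound 3 `O=C(Nc1ccc(C(F)(F)F)cc1)NC1CCN(C(=O)C2=COCC2)CC1` keeps the trifluoromethyl group but carries a different group on the carbonyl carbon: a group of 5 heavy atoms (4 carbon, 1 oxygen; one five-membered non-aromatic ring with 1 hetero atom) in place of a group of 6 heavy atoms (5 carbon, 1 oxygen; one five-membered aromatic ring with 1 hetero atom), on a carbonyl carbon. In this assay compound 3 gives 2.3 ug/mL, and the step of a 2.9-fold higher number from compound 1 to compound 3 (0.46 log units; beyond the scatter) is modest but beyond the scatter, so compound 3 sits highest of the three measured compounds, with compound 2 nearest and compound 1 furthest.

Compound 4 `O=C(Nc1ccc(OC(F)(F)F)cc1)NC1CCN(C(=O)C2=COCC2)CC1` has not yet been measured. It stands to compound 3 as compound 2 stands to compound 1: trifluoromethoxy in place of trifluoromethyl on an aromatic carbon. The place of this change is described in the same words for both pairs, so it is the same change made on a different core. Because a 1.2-fold higher number from compound 1 to compound 2 (0.06 log units; within the scatter) was within the scatter, the step from compound 3 to compound 4 is expected to be similarly small, a 1.1-fold higher number from compound 3 to compound 4 (0.05 log units; within the scatter), an expectation resting on that single earlier example. Compound 4 is therefore estimated to show 2.6 ug/mL, with a likely range from 1.3 ug/mL to 5.2 ug/mL.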

Compound 4, solubility: 11 ug/mL
For compound 4 the middle estimate is 4.2-fold (0.63 log units) below the measured one; measured number above the stated range.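

In this assay, going by these compounds alone, putting trifluoromethoxy in place of trifluoromethyl gave a 1.2-fold higher number from compound 1 to compound 2 (0.06 log units; within the scatter) on the core of compound 1, which cannot be told from no step at all, but a 4.8-fold higher number from compound 3 to compound 4 (0.68 log units; beyond the scatter) on the core of compound 3, so here the size of the step did not carry over from one core to the other. The change on the carbonyl carbon tells the same story from the other side: it gave a 2.9-fold higher number from compound 1 to compound 3 (0.46 log units; beyond the scatter) with trifluoromethyl on the aromatic ring and a 12-fold higher number from compound 2 to compound 4 (1.08 log units; beyond the scatter) with trifluoromethoxy there, so the two changes do not simply add up in these four compounds. Each step rests on a single pair, so this does not show how the change would behave on a third core, and nothing shown here explains why the two cores part ways.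

Still open, going by these compounds, is whether the same dependence on the core would appear with other groups in that place on the aromatic ring, such as a nitrile or a chlorine atom, or with an amine or a carboxylic acid on the group at the carbonyl carbon. Also open, on these data alone, is whether repeated measurements of compound 3 and compound 4 would return a step of the same size.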